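A few compounds are considered here, and "the series" means these few. Any claim that something is new, unique, unknown or untested is made for them only; others in the source may bear on it.

Among the measured compounds shown here, compound 1 `COc1ccc(C(=O)Nc2ccccc2Cl)cc1OC1CCCC1` gives 190 nM in an assay on isolated protein for inhibition of phosphodiesterase 4A (Sus scrofa) (a lower number here means a stronger inhibitor, a higher number a weaker inhibitor), the higher of the two numbers measured so far. For the measured compounds named here, the only other measured compound, compound 2 `COc1ccc(C(=O)Nc2ccccc2Br)cc1OC1CCCC1`, gives 130 nM in this assay, and the step of a 1.5-fold lower number from compound 1 to compound 2 (0.16 log units; within the scatter) lies within the scatter. Compound 3 `COc1ccc(C(=O)Nc2ccccc2O)cc1OC1CCCC1` alters compound 1 at the same place: hydroxy in place of chloro on an aromatic carbon. That single measured step, bromo in place of chloro, was small and says little about a hydroxy group there, so the expected step of a 2.1-fold higher number from compound 1 to compound 3 (0.32 log units; beyond the scatter) is a modest move towards a weaker inhibitor with wide uncertainty. Compound 3 is therefore estimated at 400 nM, between 130 nM and 1300 nM.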

Compound 3, half-maximal inhibitory concentration: 1300 nM
Compound 3: the middle estimate sits 3.3-fold (0.51 log units) below what was measured, and the stated range covers the measured number.
By their numbers in this assay, from the lowest: compounds 2 and 1 (each within the scatter of the next); then compound 3.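

This position is not indifferent to what sits on it: in this assay, hydroxy in place of chloro gives a 6.8-fold higher number from compound 1 to compound 3 (0.84 log units; beyond the scatter), and hydroxy in place of bromo gives a 10-fold higher number from compound 2 to compound 3 (1.00 log units; beyond the scatter), whereas the step between the two halogens stayed within the scatter. Hydroxy brings a hydrogen-bond donor and acceptor that chloro lacks, but these compounds cannot tie the weaker number to either feature. Nothing available explains the change. Still open, going by these compounds, is whether a methoxy group or an amine at this place would track hydroxy or the halogens.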